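Carboxy for Phenyl on an Amide Side Chain

The source may report more compounds than this note shows. Statements on the series, on what has been measured and on what is new or still open speak of the compounds shown alone.

The measured compounds, with their values in an ADME assay on A2780 cells (Homo sapiens) for cytotoxicity, read by MTT assay, with a stated time of 72 h; on this read-out lower numbers stand for stronger inhibition of growth and higher numbers for weaker inhibition of growth:
Compound 1, `O=C(O)C1C(C(=O)NCCCc2ccccc2)[C@H]2CC[C@@H]1O2`, gives 10000 nM.
Compound 2, `O=C(O)C1C(C(=O)NCC2Cc3ccsc3CO2)[C@H]2CC[C@@H]1O2`, gives 10000 nM.
Compound 3, `Cn1ccc2cc(CNC(=O)C3C(C(=O)O)[C@@H]4CC[C@H]3O4)ccc21`, gives 10000 nM.

All three share a bicyclic core carrying a carboxylic acid and an amide, and differ only in the group attached through the amide nitrogen. In this assay compound 1 stands level with compound 2 and compound 3 at the digits reported; its nearest neighbour is compound 2 and its furthest is compound 3, and in both cases the difference is within the scatter. Nothing among these three separates one side chain from another.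

Compound 4, `O=C(O)CCCNC(=O)C1C(C(=O)O)[C@@H]2CC[C@H]1O2`, has not yet been measured. It differs from compound 1 in one place: carboxy in place of phenyl on a saturated chain carbon, three bonds along the chain from an amide-type nitrogen. Going by the values given here, since the three measured side chains, aromatic or not, all sit at the same value, there is no step on record that would suggest a shift in either direction. The step expected in this assay is therefore no change at the digits printed from compound 1 to compound 4 (within the scatter), none beyond the scatter. Compound 4 is expected to give 10000 nM, within 5000 nM to 20000 nM.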

Compound 4, concentration for 50% growth inhibition: 10000 nM
For compound 4 middle estimate and measured number coincide at the digits printed; the range from low to high includes it.
By their numbers in this assay, from the lowest: compounds 1, 2, 3 and 4 (each within the scatter of the next).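

In this assay the change of phenyl to carboxy on the side chain reads no change at the digits printed from compound 1 to compound 4 (within the scatter) and so an aromatic ring on that chain is not needed to keep the number where it stands. The earlier compounds shown here all carried an aromatic ring on the side chain and could not show this, whereas compound 4 has no ring there and brings in a hydrogen-bond donor and acceptor, yet its printed value matches. No measurement at hand accounts for this flat result.

With all four compounds at one value, nothing shown reveals a side-chain change that would lower the number. An amine in place of the carboxy, or a longer chain carrying the carboxy, remains an open case.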